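A few compounds are considered here, and "the series" means these few. Any claim that something is new, unique, unknown or untested is made for them only; others in the source may bear on it.

Two compounds with a shared core carrying a bromo group and a nitro group have been measured in an assay on isolated protein for inhibition of alkaline phosphatase, tissue-nonspecific isozyme (Bos taurus), read by spectrophotometry, with stated times of 7 min and 15 min; a higher number here means a weaker inhibitor, a lower number a stronger inhibitor. Compound 1 `CCCCCc1c(Br)c(=O)c2cc([N+](=O)[O-])ccc2n1Cc1ccc(OC)cc1` gives 9510 nM in this assay. Compound 2 `Cc1ccc(-c2[nH]c3ccc([N+](=O)[O-])cc3c(=O)c2Br)cc1` gives 6470 nM in this assay. Of the two numbers that of compound 2 is the lower, but the number of compound 1 sits within the scatter of it, so the two compounds cannot be placed in any order on this evidence. The two structures differ in more than one place, so no single structural step can be read from them.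

Compound 3 `CCCCCc1[nH]c2ccc([N+](=O)[O-])cc2c(=O)c1Br` has not yet been measured in this assay. It differs from compound 2 in one place: pentyl in place of 4-methylphenyl on an aromatic carbon. For the measured compounds named here, no measured pair shows this change on its own, so the size of its effect is unknown. Compound 1, which also carries a pentyl group on this carbon, gives 9510 nM in this assay, close to compound 2. On that basis the expected step of a 1.2-fold higher number from compound 2 to compound 3 (0.09 log units; within the scatter) is small, likely within the scatter. Compound 3 is estimated at 8000 nM, with a range from 3000 nM to 25000 nM.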

Compound 3, half-maximal inhibitory concentration: 17200 nM
The estimate for compound 3 lay 2.2-fold (0.33 log units) below the measured number, within the range that was stated.
By their numbers in this assay, from the lowest: compounds 2, 1 and 3 (each within the scatter of the next, the first and the last beyond it).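

In this assay, for the compounds shown here, the swap of 4-methylphenyl for pentyl on the aromatic carbon next to the ring nitrogen, seen on its own for the first time, gives a 2.7-fold higher number from compound 2 to compound 3 (0.42 log units; beyond the scatter) and so shows that the group at this carbon does affect the number, though only modestly and in a single pair. The other change, hydrogen in place of 4-methoxybenzyl on the ring nitrogen, gives a 1.8-fold higher number from compound 1 to compound 3 (0.26 log units; within the scatter) and so cannot be told apart from repeat-measurement noise, which means that even a group this large on the nitrogen leaves no readable mark on these numbers. Nothing measured here explains the step between the ring and the chain.

As far as these compounds go, whether it is the ring itself or some particular feature of the 4-methylphenyl group that matters stays open, and a plain phenyl, a pyridine ring, or a shorter or longer chain at this carbon could help to separate the two. From the compounds shown here alone, it also remains open whether an amine or a carboxylic acid at this carbon, or a small methyl on the ring nitrogen, would move the number further than these groups do.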